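The source may report more compounds than this note shows. Statements on the series, on what has been measured and on what is new or still open speak of the compounds shown alone.

Measured compounds in a functional assay on KB cells (Homo sapiens) for antiproliferative activity, read by sulforhodamine B assay, with a stated time of 3 days; a lower number here means that less compound is needed, a higher number that more compound is needed for the effect:
- compound 1, `CCC1=C(O)c2c(oc(-c3ccc(F)cc3)cc2=O)C(CC)(CC)C1=O`: 33 uM
- compound 2, `CCC1=C(O)c2c(oc(-c3cccc(C)c3)cc2=O)C(CC)(CC)C1=O`: 49.7 uM
- compound 3, `CCC1=C(O)c2c(oc(-c3cc(C)c(C)cc3C)cc2=O)C(CC)(CC)C1=O`: 8.2 uM

All three share the same core and differ only in the aryl group attached to it. Compound 3 stands at the lowest number of the three: compound 1 sits a 4.0-fold lower number from compound 1 to compound 3 (0.60 log units; beyond the scatter) away, and compound 2 a 6.1-fold lower number from compound 2 to compound 3 (0.78 log units; beyond the scatter) away, both gaps beyond the scatter. Between compound 1 and compound 2 the difference is a 1.5-fold higher number from compound 1 to compound 2 (0.18 log units; within the scatter), which is within the scatter.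

Compound 4, `CCC1=C(O)c2c(oc(-c3cc(C)cc(C)c3)cc2=O)C(CC)(CC)C1=O`, has not yet been measured in this assay. It differs from compound 3 in one place: 3,5-dimethylphenyl in place of 2,4,5-trimethylphenyl on an aromatic carbon.

The measured steps that bear on this change are those leading to compound 3. Going from a single 3-methylphenyl to the 2,4,5-trimethylphenyl gave a 6.1-fold lower number from compound 2 to compound 3 (0.78 log units; beyond the scatter); compound 4 keeps two methyl groups rather than one or three, so it may fall somewhere between compound 2 and compound 3. Since a methyl group is lost, a somewhat higher number is expected for compound 4, with the step of a 2.4-fold higher number from compound 3 to compound 4 (0.39 log units; beyond the scatter) expected to be modest and possibly within the scatter. The estimate for compound 4 is 20 uM, with a range from 8 uM to 50 uM.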

Compound 4, concentration for half-maximal effect: 45.5 uM
Beside the measured number, compound 4's estimate is 2.3-fold (0.36 log units) below it; measured number inside the range.
By their numbers in this assay, from the lowest: compound 3; then compounds 1, 4 and 2 (each within the scatter of the next).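

In this assay, the number of methyl groups on the aryl ring does not by itself set the result: going from the 3-methylphenyl to the 3,5-dimethylphenyl gives a 1.1-fold lower number from compound 2 to compound 4 (0.04 log units; within the scatter), whereas going from the 2,4,5-trimethylphenyl to the 3,5-dimethylphenyl gives a 5.5-fold higher number from compound 3 to compound 4 (0.74 log units; beyond the scatter). The 3,5-dimethylphenyl also stays close to the 4-fluorophenyl, with a 1.4-fold higher number from compound 1 to compound 4 (0.14 log units; within the scatter), so among these four compounds only compound 3, with its 2,4,5-trimethylphenyl, stands apart from the rest. Nothing available here gives a reason for that separation.

The compounds shown leave open whether the low number of compound 3 needs all three methyl groups or could be kept with only part of that arrangement, a question that a 2,5-dimethylphenyl or a 2,4-dimethylphenyl on the shared core could help to settle. They also leave open how this position would respond to groups other than methyl and fluorine on the aryl ring, such as a methoxy group or an amine.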